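Sulfamoyl side-chain variation on a shared oxadiazole-free core series

The source may hold more compounds than are shown below. What is called first, only, known or untested is meant among the compounds shown, and "the series" means these compounds.

Measured so far:
compound 1, `NS(=O)(=O)NNc1nonc1/C(=N/O)Nc1ccc(F)c(Br)c1`, 218 nM
compound 2, `CCNS(=O)(=O)CCNc1nonc1/C(=N/O)Nc1ccc(F)c(Br)c1`, 95 nM

In an assay on isolated protein for inhibition of Indoleamine 2,3-dioxygenase 1 (Homo sapiens), read by fluorescence, with a stated time of 60 min (a lower number here means a stronger inhibitor, a higher number a weaker inhibitor), compound 1 gives 218 nM, the highest of the two numbers in hand, and the nearest neighbour is compound 2, which in this assay gives 95 nM. Among the measured compounds shown here, the only measured step, a 2.3-fold lower number from compound 1 to compound 2 (0.36 log units; beyond the scatter), replaces sulfamoylamino on a nitrogen on an aromatic ring with 2-(ethylsulfamoyl)ethyl and lowers the number modestly.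

Compound 3, `O=S(=O)(CCNc1nonc1/C(=N/O)Nc1ccc(F)c(Br)c1)NO`, is not yet measured. Its difference from compound 1 is 2-(hydroxysulfamoyl)ethyl in place of sulfamoylamino on a nitrogen on an aromatic ring. The change shares with the measured step the move from sulfamoylamino to a two-carbon-linked sulfamoyl group on the same nitrogen; it differs at the far end, where a hydroxy group stands where compound 2 carries ethyl. For the measured compounds named here, the step to compound 2 is therefore the only direct guide, and it was modest and beyond the scatter.

On that basis compound 3 is expected to land close to compound 2, estimated at 120 nM with a range of 50 nM to 300 nM, which would mean a step of a 1.8-fold lower number from compound 1 to compound 3 (0.26 log units; within the scatter), expected to be modest and downward or within the scatter.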

Compound 3, half-maximal inhibitory concentration: 126 nM
For compound 3 the middle estimate is 1.1-fold (0.02 log units) below the measured one; measured number inside the range.
By their numbers in this assay, from the lowest: compounds 2, 3 and 1 (each within the scatter of the next, the first and the last beyond it).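

In this assay, 2-(hydroxysulfamoyl)ethyl in place of sulfamoylamino on a nitrogen on an aromatic ring gives a 1.7-fold lower number from compound 1 to compound 3 (0.24 log units; within the scatter) and so, unlike the ethyl-bearing side chain of compound 2, does not separate from compound 1. Among the compounds shown here, at the far end of the new side chain, hydroxy in place of ethyl on a sulfonamide nitrogen gives a 1.3-fold higher number from compound 2 to compound 3 (0.12 log units; within the scatter), the first reading of that position: the two substituents cannot be told apart here, so the series shows that this nitrogen accepts either group without a step beyond the scatter. The three numbers therefore give no firm ranking of ethyl against hydroxy, and the measured data offer no explanation for any of these steps.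

From the compounds shown here alone, whether a sulfonamide nitrogen carrying no substituent, or one carrying a longer alkyl chain such as butyl, would stay with compounds 2 and 3 remains open. Also open, going by these compounds, is whether a propyl linker in place of the ethyl one, or a carboxylic acid or an amine in place of the sulfonamide, would keep the number near these values.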